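The source may report more compounds than this note shows. Statements on the series, on what has been measured and on what is new or still open speak of the compounds shown alone.

The measured compounds:
- compound 1, `Nc1ccn(COCCO)c(=O)n1`, gives > 400 ug/mL in a functional assay (Oryctolagus cuniculus) for inhibition; on this read-out lower numbers stand for stronger inhibition and higher numbers for weaker inhibition
- compound 2, `CC(=O)OCCOCn1cnc2c(Cl)nc(Cl)nc21`, gives 10 ug/mL in this assay
- compound 3, `Nc1nc2c(nc(Cl)n2COCCO)c(=O)[nH]1`, gives > 400 ug/mL in this assay

Compound 3 does not have a number of its own in this assay: the reading of > 400 ug/mL is a limit of the assay, meaning no inhibition was reached up to that concentration. Compound 1 sits at the same kind of limit, with > 400 ug/mL for compound 1. Going by the values given here, only compound 2 yields a real number, 10 ug/mL for compound 2, and so it is the one compound here with measurable inhibition. Two of the three readings therefore rest at the limit of > 400 ug/mL in this assay, at which 2 of the 3 values shown sit, and compound 3 is one of them.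

Compound 4, `CNc1nc2c(=O)[nH]c(N)nc2n1COCCO`, is compound 3 with one change: methylamino in place of chloro on an aromatic carbon. Among the compounds with values here, no pair of measured compounds in this set differs in just this way, so there is no measured step to lean on. Since compound 3 gives a limit rather than a number, the step to compound 4 cannot be sized from data; the expectation is that compound 4 remains near that limit, with the estimated change an at least 1.1-fold lower number from compound 3 to compound 4 (0.05 log units; that floor lies within the scatter) lying within the scatter rather than beyond it. Compound 4 is thus expected to show about 350 ug/mL in this assay, somewhere between 80 ug/mL and 1000 ug/mL.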

Compound 4, concentration for 50% inhibition: > 400 ug/mL
Compound 4: only a limit was reported; the forecaster's own chance of this, stated with the estimate: 70%; middle value at least 1.1-fold (0.05 log units) away from the limit.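

Compound 4 reads > 400 ug/mL in this assay, which is a limit and not a number. No size can be read for the step from compound 3 to compound 4, because both compounds rest at a limit: the limit of > 400 ug/mL in this assay, at which 3 of the 4 values shown sit. Going by these compounds, whether methylamino in place of chloro on an aromatic carbon changes inhibition at all remains open.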